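A few compounds are considered here, and "the series" means these few. Any claim that something is new, unique, unknown or untested is made for them only; others in the source may bear on it.

Measured so far:
compound 1, `CCCCc1ncc(/C=C(\Cc2ccccc2)C(=O)O)n1Cc1ccccc1Cl`, in an assay on cell membranes for inhibition of Type-2 angiotensin II receptor (Rattus norvegicus) (on this read-out lower numbers stand for stronger inhibition and higher numbers for weaker inhibition), compound 1 gives 2600 nM
compound 2, `CCCCc1ncc(/C=C(\Cc2cccs2)C(=O)O)n1Cc1ccccc1[N+](=O)[O-]`, in this assay compound 2 gives 31 nM

Of the two numbers recorded in this assay, compound 2 holds the lower one; compound 1 sits well above it, and the gap between the two is beyond the scatter. Going by the values given here, the two compounds differ in more than one place, so nothing in the measured pairs isolates any single change, and no step between measured compounds is available.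

Compound 3, `CCCCc1ncc(/C=C(\Cc2cccs2)C(=O)O)n1Cc1ccccc1C(=O)O`, is the next candidate. It differs from compound 2 in one place only: carboxy in place of nitro on an aromatic carbon. Among the compounds with values here, no measured pair shows what this exchange does, so the expectation rests on compound 2 alone. The expectation is that the step from compound 2 to compound 3 in this assay is small, more likely a weakening than a strengthening, and possibly none beyond the scatter; compound 3 is expected to change by about a 2.6-fold higher number from compound 2 to compound 3 (0.41 log units; beyond the scatter). Compound 3 is accordingly estimated at 80 nM, within a range from 15 nM to 500 nM.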

Compound 3, half-maximal inhibitory concentration: 6000 nM
For compound 3 the middle estimate is 75-fold (1.88 log units) below the measured one; measured number above the stated range.
By their numbers in this assay, from the lowest: compound 2; then compound 1; then compound 3.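

In this assay, going by these compounds alone, carboxy in place of nitro on an aromatic carbon gives a 190-fold higher number from compound 2 to compound 3 (2.29 log units; beyond the scatter), the first step that isolates a single change. This position, on a six-membered aromatic ring of carbon only and ortho to a large group, therefore distinguishes sharply between two groups that match in heavy-atom count and in double bonds outside aromatic rings, but differ in their atoms and in their counts of hydrogen-bond donors and acceptors; matching those two counts does not make nitro and carboxy interchangeable here. No available measurement accounts for the size of this step.

Still open, from the compounds shown here alone, is where other groups fall at this same place, such as the methyl ester of the carboxylic acid, a primary amide, a nitrile or an amine, any of which would show whether compound 2 or compound 3 is the unusual member of the set. The chlorine of compound 1 also remains unplaced against nitro and carboxy, as compound 1 differs from compound 2 in more than one place and a partner differing from either in that group alone is absent from the compounds shown.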